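Methylsulfonyl on the piperidine nitrogen of compound 1

The source may report more compounds than this note shows. Statements on the series, on what has been measured and on what is new or still open speak of the compounds shown alone.

Measured compounds:
compound 1 `CCc1ccc(N(CC(C)C)S(=O)(=O)c2ccc3c(c2)C(=O)CC(C2CCNCC2)O3)cc1` 2.21
compound 2 `CCc1ccc(N(CC(C)C)S(=O)(=O)c2ccc3c(c2)C(F)CC(C2CCOCC2)O3)cc1` 5.02

In a physicochemical assay for lipophilicity, at pH 7.4 (on this read-out higher numbers stand for higher lipophilicity and lower numbers for lower lipophilicity), compound 1 gives the lower of the two numbers; compound 2 gives 5.02, a number beyond the scatter above it. Compound 3 `CCc1ccc(N(CC(C)C)S(=O)(=O)c2ccc3c(c2)C(=O)CC(C2CCN(S(C)(=O)=O)CC2)O3)cc1` is not yet measured. It differs from compound 1 by methylsulfonyl in place of hydrogen on an amine nitrogen in a ring. Going by the values given here, no measured pair shows this change, so the step from compound 1 to compound 3 is estimated from the structures alone. A rise in this assay beyond the scatter is expected, a number 1.69 log units higher from compound 1 to compound 3 (beyond the scatter). Compound 3 is expected to give 3.9, between 3.2 and 4.6.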

Compound 3, distribution coefficient: 3.31
The estimate for compound 3 lay 0.59 log units above the measured number, within the range that was stated.
By their numbers in this assay, from the lowest: compound 1; then compound 3; then compound 2.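

In this assay, going by these compounds alone, the pair of compound 1 and compound 3 gives a direct reading at the amine nitrogen of the piperidin-4-yl group, which the earlier compounds, differing in more than one place, could not give. Methylsulfonyl in place of hydrogen there gives a number 1.10 log units higher from compound 1 to compound 3 (beyond the scatter), with the rest of the molecule unchanged. No available evidence accounts for this step.

On these data alone, whether an acetyl or a methyl group on the same nitrogen would give a similar step remains open. So does whether methylsulfonyl would give a similar step on a different core.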